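A silicon-bearing group gives way to hydrogen

The source may report more compounds than this note shows. Statements on the series, on what has been measured and on what is new or still open speak of the compounds shown alone.

Compound 1 `CSCOC1(C)COC(C)(CC(=O)OC[C@@H]2C=C(O)[C@H](n3cnc4c(N)ncnc43)O2)C1` gives 400000 nM
Compound 2 `CSCO[C@@]1(C)CO[C@@](C)(CC(=O)OC[C@H]2O[C@@H](n3cc(C)c(=O)[nH]c3=O)C[C@@H]2O[Si](C)(C)C(C)(C)C)C1` gives 80000 nM

Going by the values given here, both values come from a functional assay on C8166 cells (Homo sapiens) for cytotoxicity (a lower number here means that less compound is tolerated, a higher number that more compound is tolerated), and form the only measurements at hand. Compound 2 stands lowest of the two, and compound 1 lies beyond the scatter above it. Compound 3 `CSCO[C@@]1(C)CO[C@@](C)(CC(=O)OC[C@H]2O[C@@H](n3cc(C)c(=O)[nH]c3=O)C[C@@H]2O)C1` differs from compound 2 in one place: a hydrogen atom in place of a group of 7 heavy atoms (6 carbon, 1 silicon; no ring), on an oxygen on a saturated carbon on an oxygen on a saturated carbon. Among the compounds with values here, no measured pair shows this change alone, so the evidence is thin. Compound 1 also lacks the silicon-bearing group, though it differs elsewhere too, and its value of 400000 nM points to an upward move. In this assay the expected step is a 3.8-fold higher number from compound 2 to compound 3 (0.57 log units; beyond the scatter) and it would lie beyond the scatter, towards more compound tolerated. The estimated value for compound 3 is 300000 nM with 100000 nM to 800000 nM as its expected range.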

Compound 3, half-maximal cytotoxic concentration: 1000000 nM
Beside the measured number, compound 3's estimate is 3.3-fold (0.52 log units) below it, outside the stated range (above it).
By their numbers in this assay, from the lowest: compound 2; then compound 1; then compound 3.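

In this assay, putting hydrogen in place of the silicon-bearing group on this oxygen gives a 13-fold higher number from compound 2 to compound 3 (1.10 log units; beyond the scatter) and so moves well beyond the scatter, towards more compound tolerated. Going by these compounds alone, this pair shows the change on its own for the first time, so the gap between the two numbers belongs to this single replacement on an otherwise unchanged structure. Nothing at hand accounts for the size of the step.

Going by these compounds, it remains open whether a small group on this oxygen, such as a methyl ether or an acetyl ester, would stay near compound 2 or near compound 3, or whether the trimethylsilyl group would behave like the larger group. With a single pair, it is also unknown whether the same replacement would give a similar step on another core.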